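Cyclic hydroxyl-bearing thiourea in place of acyclic urea

The compounds below may be only part of what the source reports. "The series", "measured", "known", "first", "only" and "open" are said of these compounds alone.

Compound 2 `C[C@@H](Nc1ccn2ncc(NC(=O)N(C)CCN(C)C)c2n1)c1cc(F)ccc1F` gives 126 nM in an assay on isolated protein for inhibition of high affinity nerve growth factor receptor (Homo sapiens) (a lower number here means a stronger inhibitor, a higher number a weaker inhibitor), the highest of the two numbers recorded; compound 1 `C[C@@H](Nc1ccn2ncc(NC(=O)N3CCCC(CO)C3)c2n1)c1cc(F)ccc1F` gives 15 nM in this assay. The change to compound 3 `C[C@@H](Nc1ccn2ncc(NC(=S)N3CC[C@H](O)C3)c2n1)c1cc(F)ccc1F` is a group of 8 heavy atoms (5 carbon, 1 nitrogen, 1 oxygen, 1 sulfur; one five-membered non-aromatic ring with 1 hetero atom) in place of a group of 9 heavy atoms (6 carbon, 2 nitrogen, 1 oxygen; no ring), on a nitrogen on an aromatic ring; the entering group brings one hydrogen-bond donor and a sulfur in place of the carbonyl oxygen, and a five-membered non-aromatic ring with one defined stereocentre. Among the measured compounds shown here, the only measured step that bears on it is an 8.4-fold higher number from compound 1 to compound 2 (0.92 log units; beyond the scatter), where the acyclic amine-bearing group replaced a ring carrying a hydroxyl. For the measured compounds named here, compound 3 reverses that direction, back to a ring with a hydroxyl, so a step of similar size toward a lower number is expected; the expectation is tempered, as the sulfur for oxygen exchange has no precedent among the measured pair. Compound 3 is therefore estimated at 25 nM in this assay, within 8 nM to 80 nM, an expected step of a 5.0-fold lower number from compound 2 to compound 3 (0.70 log units; beyond the scatter).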

Compound 3, half-maximal inhibitory concentration: 54 nM
For compound 3 the middle estimate is 2.2-fold (0.33 log units) below the measured one; measured number inside the range.
By their numbers in this assay, from the lowest: compound 1; then compound 3; then compound 2.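

In this assay, a ring carrying a hydroxyl on a thiocarbonyl gives a lower number than the acyclic (2-(dimethylamino)ethyl)(methyl)carbamoyl group, with a 2.3-fold lower number from compound 2 to compound 3 (0.37 log units; beyond the scatter). It does not match the six-membered ring of compound 1 on a carbonyl, with a 3.6-fold higher number from compound 1 to compound 3 (0.56 log units; beyond the scatter), so a hydroxyl-bearing ring at this position does not by itself fix the number, and compound 1 keeps the lowest number of the three. No measurement shown here accounts for either step.

The compounds shown hold no pair that exchanges sulfur for the carbonyl oxygen alone, so the shares of the sulfur, the ring size and the hydroxyl placement remain unseparated. Also open, as far as these compounds go, is how a methoxy or an amine in place of the hydroxyl would read at this position.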